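Hydroxy to amino on the glycolamide chain: a second reading

This account rests on a few compounds, and the source may have more. Where it says the series, first, only, none or still open, it means among the compounds named here.

Measured compounds:
compound 1, `COc1ccc(C(=O)c2ccc3c(c2)C=CC(C)(C)O3)c(NC(=O)CO)c1`, 240 nM
compound 2, `COc1ccc(C(=O)c2ccc3c(c2)C=CC(C)(C)O3)c(NC(=O)CN)c1`, 580 nM
compound 3, `C=C(c1ccc2c(c1)C=CC(C)(C)O2)c1ccc(OC)cc1NC(=O)CO`, 100 nM

Three compounds were tested in a functional assay on HeLa cells (Homo sapiens) for antiproliferative activity, read by MTT assay, with a stated time of 48 h; a higher number here means a weaker inhibitor, a lower number a stronger inhibitor. Compound 1, with its hydroxy group on the chain, gives 240 nM, and compound 2, which carries the change (amino in place of hydroxy on a saturated chain carbon bound to a carbonyl carbon), gives 580 nM. That change made the step of a 2.4-fold higher number from compound 1 to compound 2 (0.38 log units; beyond the scatter). Compound 3 gives 100 nM, the lowest of the three numbers; the difference between the core of compound 3 and the core of compound 1 is not broken down here.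

Compound 4, `C=C(c1ccc2c(c1)C=CC(C)(C)O2)c1ccc(OC)cc1NC(=O)CN`, has not yet been tested. It differs from compound 3 by amino in place of hydroxy on a saturated chain carbon bound to a carbonyl carbon, the same change that led from compound 1 to compound 2. On the core of compound 1 that change gave a modest rise in the number, and the expectation for compound 4 rests on the same change recurring: the step from compound 3 to compound 4 is expected to be a 2.4-fold higher number from compound 3 to compound 4 (0.38 log units; beyond the scatter). For compound 4 the estimate in this assay is therefore 240 nM, with a range from 120 nM to 500 nM.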

Compound 4, half-maximal inhibitory concentration: 160 nM
The estimate for compound 4 lay 1.5-fold (0.18 log units) above the measured number; low and high end bracket the measured number.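

In this assay, amino in place of hydroxy on the chain gave a 1.6-fold higher number from compound 3 to compound 4 (0.20 log units; within the scatter), so on the core of compound 3 the change cannot be told apart from repeat measurement. Set beside the earlier step, the two results do not separate: the same change on two cores in this assay, a 2.4-fold higher number (0.38 log units; beyond the scatter) from compound 1 to compound 2 and a 1.6-fold higher number (0.20 log units; within the scatter) from compound 3 to compound 4, 1.5-fold (0.18 log units) apart, within the scatter of two such steps. Going by these compounds alone, this shows that the change carried from one core to the other without a detectable difference in the size of the step, but two cores make no rule for the series, and only the step on the core of compound 1 lies beyond the scatter, so the pair does not establish a firm penalty for the amino group.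

The compounds shown leave open how other groups on a saturated chain carbon bound to a carbonyl carbon would compare, such as a dimethylamino group, a carboxylic acid or a longer aminoethyl chain. They also leave open whether the step would stay the same on any core other than these two.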